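A few compounds are considered here, and "the series" means these few. Any claim that something is new, unique, unknown or untested is made for them only; others in the source may bear on it.

Measured compounds in a functional assay on J774 cells (Mus musculus) for cytotoxicity, with a stated time of 48 h; a higher number here means a weaker inhibitor, a lower number a stronger inhibitor:
compound 1 `CCOC(=O)[C@@H]1[C@@H](C(=O)OCC)N1C(=O)[C@@H]1CCCN(C(=O)[C@H](CC(C)C)NC(=O)OC(C)(C)C)C1` – > 100000 nM
compound 2 `CC(C)C[C@H](NC(=O)OC(C)(C)C)C(=O)N1CCC[C@H]1C(=O)N1[C@H](C(=O)OCc2ccccc2)[C@H]1C(=O)OCc1ccccc1` – > 125000 nM
compound 3 `CC(C)C[C@@H](NC(=O)OC(C)(C)C)C(=O)N1CCC[C@H](C(=O)N2[C@H](C(=O)O)[C@H]2C(=O)O)C1` – "not determined" (no result reported)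

Compound 1 `CCOC(=O)[C@@H]1[C@@H](C(=O)OCC)N1C(=O)[C@@H]1CCCN(C(=O)[C@H](CC(C)C)NC(=O)OC(C)(C)C)C1` gives only a limit of the assay, > 100000 nM, and not a number; this is the limit described by the limit of > 100000 nM in this assay, at which 1 of the 3 values shown sits. Compound 2 `CC(C)C[C@H](NC(=O)OC(C)(C)C)C(=O)N1CCC[C@H]1C(=O)N1[C@H](C(=O)OCc2ccccc2)[C@H]1C(=O)OCc1ccccc1` likewise returns only a limit, > 125000 nM, the one described by the limit of > 125000 nM in this assay, at which 1 of the 3 values shown sits. For compound 3 `CC(C)C[C@@H](NC(=O)OC(C)(C)C)C(=O)N1CCC[C@H](C(=O)N2[C@H](C(=O)O)[C@H]2C(=O)O)C1` no result is reported in this assay, "not determined" (no result reported). Going by the values given here, compound 1 therefore stands at one of two limits among the three entries, and no measured step between any two compounds exists in this set.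

Compound 4 `CCOC(=O)[C@H]1[C@H](C(=O)OCC)N1C(=O)[C@@H]1CCCN(C(=O)[C@H](CC(C)C)NC(=O)OC(C)(C)C)C1` is the not yet measured partner of compound 1. Compared with compound 1, the change is this: the two compounds have the same atoms and bonds and differ only in configuration as drawn: 2 of 4 stereo elements differ; a stereocentre at a saturated ring carbon is drawn S in compound 1 and R in compound 4; a stereocentre at a saturated ring carbon is drawn S in compound 1 and R in compound 4. Because compound 1 sits at the limit (the limit of > 100000 nM in this assay, at which 1 of the 3 values shown sits), and because the shared core of compound 2 also sits at a limit (the limit of > 125000 nM in this assay, at which 1 of the 3 values shown sits), the account expects no step beyond the scatter for compound 4: the expected step is a step that the limit leaves unreadable from compound 1 to compound 4, with compound 4 also likely to return only a limit. The estimate for compound 4 in this assay is 150000 nM, with a range from 50000 nM to 500000 nM.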

Compound 4, half-maximal inhibitory concentration: > 100000 nM
Compound 4: no number, only a limit; the forecaster's own chance of this, stated with the estimate: 85%; the middle value does not contradict the limit.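

In this assay, going by these compounds alone, compound 4 gives only a limit, > 100000 nM, not a number, the same kind of result as compound 1, so no step between these two compounds can be read. The compounds shown leave open whether the two configurations drawn in compound 1 and compound 4 would differ at all if either gave a measurable number.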